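Swapping one heteroaromatic ring for another on a shared core

The source may hold more compounds than are shown below. What is called first, only, known or untested is meant among the compounds shown, and "the series" means these compounds.

Compound 1 `CC(C)Oc1cc(Oc2ccc(S(C)(=O)=O)cc2)cc(-c2cccc(=O)[nH]2)c1` and compound 2 `CC(C)Oc1cc(Oc2ccc(S(C)(=O)=O)cc2)cc(-c2cncc(=O)[nH]2)c1` share a core and differ only in the heteroaromatic ring attached to it. In a physicochemical assay for lipophilicity, using the shake flask method (a higher number here means a more lipophilic compound, a lower number a more polar compound), compound 1 gives 2.82, while compound 2 gives 2.27, which is the lowest of the two numbers available; compound 3 `CC(C)Oc1cc(Oc2ccc(S(C)(=O)=O)cc2)cc(-c2ncc(C(C)C)c(=O)[nH]2)c1` gives "not determined" (no result reported) in this assay. Going by the values given here, the one step measured so far, a number 0.55 log units lower from compound 1 to compound 2 (beyond the scatter), shows that changing this ring can move the read-out well beyond the scatter. Compound 4 `COc1cnc(-c2cc(Oc3ccc(S(C)(=O)=O)cc3)cc(OC(C)C)c2)[nH]c1=O` is the next compound to be measured. It differs from compound 2 in the same region: a group of 9 heavy atoms (5 carbon, 2 nitrogen, 2 oxygen; one six-membered aromatic ring with 2 hetero atoms) in place of a group of 7 heavy atoms (4 carbon, 2 nitrogen, 1 oxygen; one six-membered aromatic ring with 2 hetero atoms), on an aromatic carbon. The entering group carries one more hydrogen-bond acceptor than the leaving group, and sits meta to a large group and meta to an isopropoxy group. Among the compounds with values here, no measured pair mirrors this exact exchange, so the estimate leans on the only measured step and stays cautious. The expected step of a number 0.18 log units higher from compound 2 to compound 4 (within the scatter) is small, at most around the scatter, so compound 4 is expected to give 2.45, plausibly between 1.95 and 2.95.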

Compound 4, distribution coefficient: 2.21
The estimate for compound 4 lay 0.24 log units above the measured number; low and high end bracket the measured number.
By their numbers in this assay, from the lowest: compounds 4 and 2 (each within the scatter of the next); then compound 1.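

In this assay, the group on the shared core can grow from 7 to 9 heavy atoms, gaining a hydrogen-bond acceptor, without the read-out moving beyond the scatter (a number 0.06 log units lower from compound 2 to compound 4 (within the scatter)). The larger change, which also alters the hetero atoms in the ring, still shows a clear difference (a number 0.61 log units lower from compound 1 to compound 4 (beyond the scatter)), so compound 2 and compound 4 both lie apart from compound 1 by a similar margin. Nothing measured here explains why the added atoms leave the number essentially in place.

As far as these compounds go, it remains open whether an amine or a carboxylic acid on this ring would leave the read-out just as steady. Also open, from the compounds shown here alone, is whether a longer chain there would do the same, or whether the added atoms would behave alike on the ring of compound 1.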